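A few compounds are considered here, and "the series" means these few. Any claim that something is new, unique, unknown or untested is made for them only; others in the source may bear on it.

Compound 1 `COc1cc2c(cc1OC)C(CC(=O)Nc1cccc(Cl)c1)CC2` gives 63.3% in a functional assay on the whole organism (strain Wistar) for inhibition, with Rattus norvegicus as the target, read by paw edema, with a stated time of 24 h, at a dose of 100 mg/kg; a higher number here means more inhibition at the dose given (going by the name of the read-out), a lower number less inhibition.
Compound 2 `COc1cc2c(cc1OC)C(CC(=O)Nc1ccc(Cl)cc1)CC2` gives 70% in this assay.
Compound 3 `COc1cc2c(cc1OC)C(CC(=O)Nc1cccc(C)c1)CC2` gives 41.7% in this assay.

On these numbers compound 1 stands second highest of three. Its nearest neighbour is compound 2, with a number 6.7 percentage points higher from compound 1 to compound 2 (within the scatter), a difference that lies within the scatter; its furthest is compound 3, with a number 21.6 percentage points lower from compound 1 to compound 3 (beyond the scatter), which lies beyond it.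

Compound 4 `COc1cc2c(cc1OC)C(CC(=O)Nc1ccc(C)cc1)CC2` has not yet been measured. It differs from compound 1 in one place: 4-methylphenyl in place of 3-chlorophenyl on an amide-type nitrogen. Two of the measured steps bear on this change. Exchanging 3-chlorophenyl for 4-chlorophenyl, a number 6.7 percentage points higher from compound 1 to compound 2 (within the scatter), made no difference beyond the scatter. Exchanging chloro for methyl, a number 21.6 percentage points lower from compound 1 to compound 3 (beyond the scatter), lowered the number by a modest amount, and the parallel step a number 28.3 percentage points lower from compound 2 to compound 3 (beyond the scatter) went the same way. The change to compound 4 combines both exchanges, so the methyl step is expected to set the direction. A modest drop is therefore expected in this assay, about a number 18.3 percentage points lower from compound 1 to compound 4 (beyond the scatter). Compound 4 is estimated at 45%, within the range 32% to 58%.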

Compound 4, a percentage reported as inhibition, in the whole organism at one dose (the size of the read-out at that dose, not a potency): 30%
Compound 4: the middle estimate sits 15 percentage points above what was measured, and the stated range ends above it.
By their numbers in this assay, from the lowest: compound 4; then compound 3; then compounds 1 and 2 (each within the scatter of the next).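

In this assay, exchanging 3-methylphenyl for 4-methylphenyl matters, with a number 11.7 percentage points lower from compound 3 to compound 4 (beyond the scatter), whereas the matching chloro exchange gave a number 6.7 percentage points higher from compound 1 to compound 2 (within the scatter). The full change from 3-chlorophenyl to 4-methylphenyl is large, with a number 33.3 percentage points lower from compound 1 to compound 4 (beyond the scatter), so the place of the group on the phenyl ring counts for methyl in a way the chloro pair did not show. Methyl in place of chloro also costs more starting from 4-chlorophenyl, with a number 40 percentage points lower from compound 2 to compound 4 (beyond the scatter), than starting from 3-chlorophenyl, so the size of this change depends on the starting group: the same change on two cores in this assay, a number 21.6 percentage points lower (beyond the scatter) from compound 1 to compound 3 and a number 40 percentage points lower (beyond the scatter) from compound 2 to compound 4, 18.4 percentage points apart, beyond the scatter of two such steps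

Only chloro and methyl are shown on this ring, so how a methoxy or a trifluoromethyl group would compare remains open. Going by these compounds, a plain phenyl as the reference point, which would show whether chloro raises the number or methyl lowers it, also remains open.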